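This account rests on a few compounds, and the source may have more. Where it says the series, first, only, none or still open, it means among the compounds named here.

Compound 1 `Cc1ncc([N+](=O)[O-])n1CCSC(=S)N1CCC(OC(=O)CSC(=S)N2CCCC2)CC1` carries a nitro-bearing heterocycle joined through a sulfur-rich linker to a ring bearing an ester. Among the measured compounds shown here, in an ADME assay on HeLa cells (Homo sapiens) for cytotoxicity (on this read-out lower numbers stand for stronger inhibition and higher numbers for weaker inhibition), compound 1 gives > 1000 ug/mL, which is a limit of the assay and not a number, the one value sitting at the limit of > 1000 ug/mL in this assay, at which 1 of the 3 values shown sits. Two relatives give numbers: compound 2 `CCC1CCCCN1C(=S)SCCn1c([N+](=O)[O-])cnc1C` shows 94 ug/mL in this assay, and compound 3 `Cc1ncc([N+](=O)[O-])n1CCSC(=S)N1C(C)CCCC1C` shows 130 ug/mL. Compound 4 `Cc1ncc([N+](=O)[O-])n1CCSC(=S)N1CCC(OC(=O)CCl)CC1` is the untested analogue. It differs from compound 1 in this way: one chlorine atom in place of a group of 8 heavy atoms (5 carbon, 1 nitrogen, 2 sulfur; one five-membered non-aromatic ring with 1 hetero atom), on a saturated chain carbon bound to a carbonyl carbon. For the measured compounds named here, no measured pair here differs in a single place, so the size of such a step is unknown. Compound 1 sits at the limit while compound 2 and compound 3 give ordinary numbers. The step from compound 1 to compound 4 is expected to be an at least 3.3-fold lower number from compound 1 to compound 4 (0.52 log units; beyond the scatter), toward stronger inhibition. Compound 4 is estimated at 300 ug/mL, within a range from 60 ug/mL to 1000 ug/mL.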

Compound 4, half-maximal inhibitory concentration: 930 ug/mL
For compound 4 the middle estimate is 3.1-fold (0.49 log units) below the measured one, and the stated range covers the measured number.
By their numbers in this assay, from the lowest: compounds 2 and 3 (each within the scatter of the next); then compound 4. At a limit, above all of these: compound 1.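

In this assay compound 4, with chloro on the saturated chain carbon bound to a carbonyl carbon, gives 930 ug/mL, a number and not a limit. The change gives an at least 1.0-fold lower number from compound 1 to compound 4 (0.03 log units; that floor lies within the scatter), so replacing the large group with a single chlorine atom may shift the read-out little or not at all, and its true size cannot be read. The value of compound 1 is a limit: the limit of > 1000 ug/mL in this assay, at which 1 of the 4 values shown sits.

On these data alone, what an amine or a carboxylic acid at this place would give remains open. So does whether a longer chain carrying the chloro group would lower the number.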